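The compounds below may be only part of what the source reports. "The series", "measured", "known", "first", "only" and "open" are said of these compounds alone.

Compound 1 `COC(=O)c1scc(-c2ccc(NC(=O)c3ccc4ccccc4c3)cc2)c1OC` carries a naphthalen-2-yl group on the carbonyl carbon of its amide. In an ADME assay on HEK293 cells (Homo sapiens) for cytotoxicity, read by MTT assay, with a stated time of 24 h (a higher number here means a weaker inhibitor, a lower number a stronger inhibitor), compound 1 gives "not determined" (no result reported), so no single number places it on the scale. Compound 3 `COC(=O)c1scc(-c2ccc(NC(=O)c3ccc(C#N)nc3)cc2)c1OC` likewise gives "not determined" (no result reported) in this assay. Compound 2 `COC(=O)c1scc(-c2ccc(NC(=O)c3ccc(C(F)(F)F)cc3Br)cc2)c1OC` gives > 50000 nM in this assay, which is a limit of the assay and not a number. Compound 4 `COC(=O)c1scc(-c2ccc(NC(=O)c3ccc(C(F)(F)F)cc3)cc2)c1OC` differs from compound 1 by 4-(trifluoromethyl)phenyl in place of naphthalen-2-yl on a carbonyl carbon. Within the data shown here, since compound 1 has no number, no step can be measured for it, and only the one limit gives any footing. Because the limit of > 50000 nM in this assay, at which 1 of the 3 values shown sits, is the only reported position, compound 4 is expected near 50000 nM, in a range from 25000 nM to 100000 nM, most likely reported as a limit again.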

Compound 4, half-maximal inhibitory concentration: 48300 nM
For compound 4 the middle estimate is 1.0-fold (0.02 log units) above the measured one; the measured number falls inside the stated range.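

In this assay, among these compounds, compound 4 gives the first actual number at this position, 48300 nM. Compound 2 gives > 50000 nM, which is a limit and not a number. Hydrogen in place of bromo on an aromatic carbon gives an at least 1.0-fold lower number from compound 2 to compound 4 (0.01 log units; that floor lies within the scatter), so the change shows no shift beyond the scatter, though its true size stays unknown.

The change from naphthalen-2-yl to 4-(trifluoromethyl)phenyl cannot be read, since compound 1 has no number. Going by these compounds, how an amine or a carboxylic acid in place of the trifluoromethyl group would read in this assay remains open.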